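A few compounds are considered here, and "the series" means these few. Any claim that something is new, unique, unknown or untested is made for them only; others in the source may bear on it.

Compound 1 `CCCCNC(=O)/C=C/[C@H]1C[C@@H](O)[C@@H](O)C1` gives > 250000 nM in an ADME assay on S2 cells (Drosophila melanogaster) for cytotoxicity, read by MTT assay (a higher number here means that more compound is needed for the effect, a lower number that less compound is needed), which is a limit of the assay and not a number. Compound 2 `O=C(/C=C/[C@H]1C[C@@H](O)[C@@H](O)C1)NO` gives > 250000 nM in this assay, again a limit rather than a number.

Compound 2 therefore stands at the limit in this assay, as does (the limit of > 250000 nM in this assay, at which 2 of the 2 values shown sit). Within the data shown here, the one step among the measured compounds, a step that the two limits leave unreadable from compound 1 to compound 2, is hidden by the two limits, so its size cannot be read. Compound 3 `O=C(O)/C=C/[C@H]1C[C@@H](O)[C@@H](O)C1` is not yet measured and differs from compound 2 in one place: hydroxy in place of hydroxyamino on a carbonyl carbon. No readable step bears on this change, so no direction can be drawn from the measured pair, and the most that the data support is that compound 3 is expected to sit where compound 2 sits, with a change of about a number no higher from compound 2 to compound 3 (the limit leaves the size open) expected. For compound 3 in this assay the estimate is 250000 nM, in the range 100000 nM to 1000000 nM, most likely reported as a limit again.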

Compound 3, half-maximal effective concentration: > 350000 nM
Compound 3 was reported as a limit; the forecaster's own chance of this, stated with the estimate: 85%; middle value at least 1.4-fold (0.14 log units) away from the limit.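

Compound 3 gives > 350000 nM in this assay, which is a limit and not a number. Among these compounds, with compound 1, compound 2 and compound 3 all reported as limits, no step among them can be read. The compounds shown leave open how much of each produces the effect, and whether they differ at all.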